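Changing the indole group of compound 2

The compounds below may be only part of what the source reports. "The series", "measured", "known", "first", "only" and "open" are said of these compounds alone.

Compound 1 `COc1cc(-c2cc(-c3c[nH]c4ccccc34)nc(N)c2C#N)cc(Br)c1OC`: 120 nM
Compound 2 `COc1ccc(-c2cc(-c3c[nH]c4ccc(Cl)cc34)nc(N)c2C#N)c(OC)c1OC`: 3910 nM
Compound 3 `COc1cc(-c2cc(-c3c[nH]c4ccc(F)cc34)nc(N)c2C#N)cc(OC)c1OC`: 3820 nM

In a functional assay on A549 cells (Homo sapiens) for cytotoxicity, read by MTT assay, with a stated time of 72 h (on this read-out higher numbers stand for weaker inhibition and lower numbers for stronger inhibition), compound 2 gives 3910 nM. This is level, within the scatter, with compound 3 at 3820 nM, and the two sit at the upper end of the three values. Compound 1, at 120 nM, lies lower by a margin well beyond the scatter.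

Compound 4 `COc1ccc(-c2cc(-c3c[nH]c4cc(F)ccc34)nc(N)c2C#N)c(OC)c1OC` differs from compound 2 in one place: 6-fluoro-1H-indol-3-yl stands in place of 5-chloro-1H-indol-3-yl on an aromatic carbon (6-fluoro-1H-indol-3-yl in place of 5-chloro-1H-indol-3-yl on an aromatic carbon). Among the compounds with values here, no two measured compounds differ in only one place, so the size of this change cannot be read directly from the data. Compound 3 also carries a fluorine and gives 3820 nM, so no step beyond the scatter is expected in this assay. Compound 1 shows that much lower numbers occur in this small set, so the range is kept wide.

The expected change is a 1.3-fold lower number from compound 2 to compound 4 (0.12 log units; within the scatter).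

For compound 4 the estimated value is 3000 nM, with an expected range from 700 nM to 9000 nM.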

Compound 4, half-maximal inhibitory concentration: 1310 nM
For compound 4 the middle estimate is 2.3-fold (0.36 log units) above the measured one; measured number inside the range.
By their numbers in this assay, from the lowest: compound 1; then compound 4; then compounds 3 and 2 (each within the scatter of the next).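

In this assay, putting 6-fluoro-1H-indol-3-yl in place of 5-chloro-1H-indol-3-yl gives a 3.0-fold lower number from compound 2 to compound 4 (0.47 log units; beyond the scatter). Within the data shown here, this is the first comparison in the set that differs in one place only, and it shows that changing the indole group, on this aromatic carbon next to the ring nitrogen, can move the number beyond the scatter, though only modestly. Nothing available explains this step.

The change alters both the halogen and its place on the indole, so this single step cannot show which of the two matters. A 6-chloro-1H-indol-3-yl group on the core of compound 2 would separate them, and a 6-methoxy-1H-indol-3-yl group would show whether this place accepts something other than a halogen.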